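Shortening a Propyl Chain on a Weak Inhibitor

This account rests on a few compounds, and the source may have more. Where it says the series, first, only, none or still open, it means among the compounds named here.

Compound 3 `C=CCSc1nncc2cnc(CCC)n12` was tested in a functional assay for inhibition, with Homo sapiens as the target; on this read-out lower numbers stand for stronger inhibition and higher numbers for weaker inhibition. For compound 3 the read-out is only a limit of the assay, > 48000 nM. Two related compounds give numbers: compound 1 `CCOC(=O)CSc1nncc2cnc(C)n12` reaches 52000 nM in this assay, and compound 2 `CCCc1nc(C)c2cnn(C)c(=O)n12` reaches 20000 nM. Compound 3 thus sits at the limit (the limit of > 48000 nM in this assay, at which 1 of the 3 values shown sits). Compound 4 `C=CCSc1nncc2cnc(C)n12` has not yet been measured. It differs from compound 3 by hydrogen in place of ethyl on a saturated chain carbon bound to an aromatic carbon. For the measured compounds named here, no measured pair shows this change, so the step from compound 3 to compound 4 can only be judged by expectation, and a modest step in either direction, or none beyond the scatter, seems plausible. Compound 4 is expected to give about 50000 nM in this assay, within 15000 nM to 150000 nM, corresponding to an expected step that the limit leaves unreadable from compound 3 to compound 4.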

Compound 4, half-maximal inhibitory concentration: 61000 nM
Compound 4: middle estimate off by 1.2-fold (0.09 log units), on the low side; the measured number falls inside the stated range.
By their numbers in this assay, from the lowest: compound 2; then compounds 1 and 4 (each within the scatter of the next).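

Changing ethoxycarbonyl to vinyl on a saturated chain carbon bound to a sulfur gives a 1.2-fold higher number from compound 1 to compound 4 (0.07 log units; within the scatter) in this assay, so with methyl on the shared core, these two groups cannot be told apart here. Compound 4 gives the methyl end of the propyl to methyl change a real number, but the step itself cannot be read, as compound 3 carries only a limit: the limit of > 48000 nM in this assay, at which 1 of the 4 values shown sits.

The compounds shown leave open whether propyl and methyl differ at all in this assay. They also leave open whether an amine or a carboxylic acid in place of the vinyl would move the number beyond the scatter.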